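Swapping the aryl group on the azetidinone core of compound 3

The source may hold more compounds than are shown below. What is called first, only, known or untested is meant among the compounds shown, and "the series" means these compounds.

Of the compounds shown here, three sharing one core have been measured in a functional assay on MCF7 cells (Homo sapiens) for antiproliferative activity, read by MTT assay, with stated times of 24 h and 72 h; a lower number here means a stronger inhibitor, a higher number a weaker inhibitor. Compound 1 `COc1cc(N2C(=O)[C@@H](Oc3ccccc3)[C@H]2c2ccc3ccccc3c2)cc(OC)c1OC` gives 282000 nM, compound 2 `COc1cc(N2C(=O)[C@@H](Oc3ccccc3)[C@H]2c2ccc(N=[N+]=[N-])cc2)cc(OC)c1OC` gives 23000 nM, and compound 3 `COc1cc([C@@H]2[C@H](Oc3ccccc3)C(=O)N2c2cc(OC)c(OC)c(OC)c2)ccc1O` gives 32000 nM. Compound 3 thus stands second highest of the three numbers, with compound 2 closest to it and compound 1 furthest away: the step of an 8.8-fold lower number from compound 1 to compound 3 (0.95 log units; beyond the scatter) lies beyond the scatter, whereas the step of a 1.4-fold higher number from compound 2 to compound 3 (0.14 log units; within the scatter) lies within it.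

Compound 4 `COc1ccc([C@@H]2[C@H](Oc3ccccc3)C(=O)N2c2cc(OC)c(OC)c(OC)c2)cc1N` is the next member. It differs from compound 3 only at the aryl group on the saturated ring carbon: 3-amino-4-methoxyphenyl in place of 4-hydroxy-3-methoxyphenyl on a saturated ring carbon

Among the measured compounds shown here, two measured steps bear on this change. The step of a 12-fold lower number from compound 1 to compound 2 (1.09 log units; beyond the scatter) and the step of an 8.8-fold lower number from compound 1 to compound 3 (0.95 log units; beyond the scatter) both show that replacing the naphthalen-2-yl group with a substituted phenyl lowers the number markedly, while the step of a 1.4-fold higher number from compound 2 to compound 3 (0.14 log units; within the scatter) shows that exchanging one substituted phenyl for another leaves the number within the scatter. Since compound 4 keeps a substituted phenyl at this position, the expected step of a 1.3-fold lower number from compound 3 to compound 4 (0.11 log units; within the scatter) is small and not clearly beyond the scatter. Compound 4 is therefore estimated at 25000 nM, with a range from 8000 nM to 80000 nM.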

Compound 4, half-maximal inhibitory concentration: 12200 nM
For compound 4 the middle estimate is 2.0-fold (0.31 log units) above the measured one; low and high end bracket the measured number.
By their numbers in this assay, from the lowest: compounds 4, 2 and 3 (each within the scatter of the next, the first and the last beyond it); then compound 1.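

The aryl position on the saturated ring carbon proves able to separate two substituted phenyl groups: in this assay, a 2.6-fold lower number from compound 3 to compound 4 (0.42 log units; beyond the scatter) goes beyond the scatter, although the leaving and entering groups match in heavy-atom count, hydrogen-bond donors and hydrogen-bond acceptors. This distinction is limited, since a 1.9-fold lower number from compound 2 to compound 4 (0.28 log units; within the scatter) stays within the scatter, so 3-amino-4-methoxyphenyl cannot be told apart from 4-azidophenyl, just as 4-azidophenyl could not be told apart from 4-hydroxy-3-methoxyphenyl. With a 23-fold lower number from compound 1 to compound 4 (1.36 log units; beyond the scatter), a third substituted phenyl group also stands well clear of naphthalen-2-yl, so all three compounds with a substituted phenyl here, compound 2, compound 3 and compound 4, lie apart from compound 1.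

No measurement available here accounts for the difference between the amino-bearing and hydroxy-bearing groups. As far as these compounds go, it remains open how a carboxylic acid or a dimethylamino group in place of the amino group of compound 4 would read in this assay, and whether the amino group would give a similar number without the methoxy group on the same ring.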